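The source may hold more compounds than are shown below. What is called first, only, known or untested is meant among the compounds shown, and "the series" means these compounds.

Compound 1 `CCC(C)[C@H](NC[C@H](C)N)c1cc(C(F)(F)F)ccc1N1CCN(C(=O)CCc2ccc(Cl)cc2Cl)CC1` in an assay on HEK293 cells for displacement of a labelled ligand from Melanocortin receptor 4 (Homo sapiens) (a higher number here means a weaker inhibitor, a lower number a stronger inhibitor), gives 89 nM.
Compound 2 `CCC(C)[C@H](NC[C@H]1CCCN1)c1cc(C(F)(F)F)ccc1N1CCN(C(=O)CCc2ccc(Cl)cc2Cl)CC1` gives 110 nM.
Compound 3 `CCC(C)[C@H](NC(=O)OC)c1cc(C(F)(F)F)ccc1N1CCN(C(=O)CCc2ccc(Cl)cc2Cl)CC1` gives 2400 nM.

Compound 3 has the highest number of the three, set apart from compound 1 by a 27-fold higher number from compound 1 to compound 3 (1.43 log units; beyond the scatter) and from compound 2 by a 22-fold higher number from compound 2 to compound 3 (1.34 log units; beyond the scatter). Compound 4 `CCN[C@@H](CC(C)C)c1cc(C(F)(F)F)ccc1N1CCN(C(=O)CCc2ccc(Cl)cc2Cl)CC1` differs from compound 3 by 1-(ethylamino)-3-methylbutyl in place of 1-((methoxycarbonyl)amino)-2-methylbutyl on an aromatic carbon. Among the compounds with values here, both measured steps that bear on this position swapped an amine-bearing group for the methoxycarbonyl and gave large rises; compound 4 brings an amine back, though a different one, and also alters the branched chain, which no measured pair covers. A large drop is therefore expected, estimated as an 8.0-fold lower number from compound 3 to compound 4 (0.90 log units; beyond the scatter), leaving compound 4 at 300 nM with a range of 80 nM to 1200 nM.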

Compound 4, inhibition constant: 170 nM
For compound 4 the middle estimate is 1.8-fold (0.25 log units) above the measured one, within the range that was stated.
By their numbers in this assay, from the lowest: compounds 1, 2 and 4 (each within the scatter of the next); then compound 3.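

The drop in the number on going to the simple 1-(ethylamino)-3-methylbutyl group (a 14-fold lower number from compound 3 to compound 4 (1.15 log units; beyond the scatter)) is large. Compound 4 nevertheless sits level with the compounds carrying a second amine (a 1.5-fold higher number from compound 2 to compound 4 (0.19 log units; within the scatter); a 1.9-fold higher number from compound 1 to compound 4 (0.28 log units; within the scatter)), so in this assay that second amine is not required at this position. No measurement shown gives a reason for these numbers.

As far as these compounds go, compound 4 changes both the nitrogen substituent and the branched chain, so their separate shares remain unknown. Also open, from the compounds shown here alone, is how a free primary amine or a longer chain on that nitrogen would read.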